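This account rests on a few compounds, and the source may have more. Where it says the series, first, only, none or still open, it means among the compounds named here.

Compound 1 `CCCCOCNc1n[n+]([O-])c2ccccc2[n+]1[O-]` belongs to a small set of three compounds that share one core and differ only in the chain attached through an oxygen and a nitrogen. In a functional assay on KB cells (Homo sapiens) for cytotoxicity, read by MTT assay, with a stated time of 72 h (on this read-out lower numbers stand for stronger inhibition and higher numbers for weaker inhibition), compound 1 gives 15200 nM, the highest of the three numbers. Compound 2 `COCNc1n[n+]([O-])c2ccccc2[n+]1[O-]` gives 9070 nM in this assay, and compound 3 `CC(C)CCOCNc1n[n+]([O-])c2ccccc2[n+]1[O-]` gives 5210 nM. The steps among them are small: a 1.7-fold lower number from compound 1 to compound 2 (0.22 log units; within the scatter), a 2.9-fold lower number from compound 1 to compound 3 (0.47 log units; beyond the scatter), and a 1.7-fold lower number from compound 2 to compound 3 (0.24 log units; within the scatter). Taken together, shortening the chain or adding a methyl to it moves the number down only a little, and only one of these steps reaches beyond the scatter.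

Compound 4 `CCCCCCCOCNc1n[n+]([O-])c2ccccc2[n+]1[O-]` is not yet measured. It differs from compound 1 in one place: propyl in place of hydrogen on a saturated chain carbon, four bonds along the chain from an oxygen on a saturated carbon. This is again a change in chain length, of the same kind as the measured steps. Since those steps were small and all pointed to lower numbers, a lengthened chain in compound 4 is expected to give at most a modest lowering, with no certainty that it leaves the scatter. Compound 4 is therefore estimated at 8000 nM, within a range from 3000 nM to 22000 nM, which corresponds to an expected step of a 1.9-fold lower number from compound 1 to compound 4 (0.28 log units; within the scatter).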

Compound 4, half-maximal inhibitory concentration: 14000 nM
Estimate against measurement, compound 4: 1.8-fold (0.24 log units) below; low and high end bracket the measured number.
By their numbers in this assay, from the lowest: compounds 3, 2, 4 and 1 (each within the scatter of the next, the first and the last beyond it).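

In this assay, lengthening the chain of compound 1 by a propyl at this place changes nothing that can be read, with a 1.1-fold lower number from compound 1 to compound 4 (0.04 log units; within the scatter). The same holds against the short chain of compound 2, since hexyl in place of hydrogen on the saturated chain carbon bound to the oxygen gives a 1.5-fold higher number from compound 2 to compound 4 (0.19 log units; within the scatter), so among compounds 1, 2 and 4 the length of the straight chain makes no difference that stands out from the scatter. Among these compounds, compound 3 goes against this picture: pentyl in place of isopropyl gives a 2.7-fold higher number from compound 3 to compound 4 (0.43 log units; beyond the scatter), the one new step beyond the scatter, which suggests that the shape of the chain may count for more here than its length, though this rests on a single branched compound.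

Still open, going by these compounds, is how this place would respond to a chain ending in an amine or a carboxylic acid, to a phenyl ring, or to a chain much longer than that of compound 4. Nothing measured here offers a reason for any of these numbers.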